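Sulfamoyl in place of amino: expected inactivity holds

The source may report more compounds than this note shows. Statements on the series, on what has been measured and on what is new or still open speak of the compounds shown alone.

Three compounds of the series share one core and differ only in the aryl group on an aromatic nitrogen. Compound 1 `N#CC1=C(N)Oc2c(c3nc4ccccc4nc3c3ccccc23)C12C(=O)N(Cc1cnnn1-c1ccccc1Cl)c1ccccc12` carries a 2-chlorophenyl there; in a functional assay on MCF7 cells (Homo sapiens) for antiproliferative activity, read by MTT assay, with a stated time of 48 h (on this read-out lower numbers stand for stronger inhibition and higher numbers for weaker inhibition), compound 1 gives > 50000 nM, which is a limit of the assay and not a number. Compound 2 `COc1ccc(-n2nncc2CN2C(=O)C3(C(C#N)=C(N)Oc4c3c3nc5ccccc5nc3c3ccccc43)c3ccccc32)cc1` carries a 4-methoxyphenyl; in this assay compound 2 gives > 50000 nM, again a limit. Compound 3 `N#CC1=C(N)Oc2c(c3nc4ccccc4nc3c3ccccc23)C12C(=O)N(Cc1cnnn1-c1ccc(N)cc1)c1ccccc12` carries a 4-aminophenyl; in this assay compound 3 gives > 50000 nM, also a limit. Compound 3 therefore stands at the same limit as both others, as summarised by the limit of > 50000 nM in this assay, at which 3 of the 3 values shown sit. The steps a step that the two limits leave unreadable from compound 1 to compound 2, a step that the two limits leave unreadable from compound 1 to compound 3 and a step that the two limits leave unreadable from compound 2 to compound 3 are all unreadable, since every value is a limit.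

Compound 4 `N#CC1=C(N)Oc2c(c3nc4ccccc4nc3c3ccccc23)C12C(=O)N(Cc1cnnn1-c1ccc(S(N)(=O)=O)cc1)c1ccccc12` is the next member: sulfamoyl in place of amino on an aromatic carbon. Within the data shown here, no measured step bears on this change in a readable way; the only evidence is that all three aryl variants so far sit at the limit. On this basis compound 4 is expected to remain at or near that limit in this assay, with the estimate 60000 nM and a range from 20000 nM to 200000 nM. The step from compound 3 to compound 4 is thus estimated as a step that the limit leaves unreadable from compound 3 to compound 4, i.e. no change beyond scatter, most likely reported as a limit again.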

Compound 4, half-maximal inhibitory concentration: > 50000 nM
Compound 4 gave a limit, no number; the forecaster's own chance of this, stated with the estimate: 85%; the middle value lies beyond the limit too.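

In this assay compound 4 gives > 50000 nM, a limit and not a number. The steps to compound 4 from compound 1, compound 2 and compound 3 therefore cannot be read, and the series sits at one limit: the limit of > 50000 nM in this assay, at which 4 of the 4 values shown sit.

The compounds shown leave open how far each lies beyond that limit, and whether any aryl group on the shared core gives a measurable value.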